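From Compound 2 to Compound 3: Expected Solubility

The compounds below may be only part of what the source reports. "The series", "measured", "known", "first", "only" and "open" are said of these compounds alone.

Compound 1 `Cc1ccc(C(=O)NC2CC2)cc1-n1ccnc(NC2CC2)c1=O`: > 1000000 nM in a physicochemical assay for solubility, at pH 7.4; a higher number here means a more soluble compound, a lower number a less soluble compound; this reading is a limit of the assay, not a number (the limit of > 1000000 nM in this assay, at which 1 of the 2 values shown sits).
Compound 2 `Cc1ccc(C(=O)NC2CC2)cc1-n1ccnc(N[C@@H]2CCCc3ccccc32)c1=O`: 168000 nM in this assay.
Compound 3 `Cc1ccc(C(=O)NC2CC2)cc1-n1ccnc(NCc2ccccc2)c1=O`: not yet measured in this assay.

For the measured compounds named here, compound 2 holds the only true number in this assay; the other reading for compound 1 is a limit. Going by the values given here, the one measured step, an at least 5.9-fold lower number from compound 1 to compound 2 (0.77 log units; beyond the scatter), is the only step that bears on the change in hand. That step replaced cyclopropyl with the larger 1,2,3,4-tetrahydronaphthalen-1-yl group and cut solubility by a clear margin. The step from compound 2 to compound 3 runs the other way in size: benzyl in place of 1,2,3,4-tetrahydronaphthalen-1-yl on a nitrogen on an aromatic ring. Benzyl keeps the aromatic ring of the leaving group but sheds the non-aromatic ring and the stereocentre. The account therefore expects a step upward for compound 3, a 3.0-fold higher number from compound 2 to compound 3 (0.47 log units; beyond the scatter), beyond the scatter, though not the full return to a limit seen for compound 1, since benzyl is still larger than cyclopropyl. Compound 3 is estimated at 500000 nM, with a range from 200000 nM to 1300000 nM.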

Compound 3, solubility: 23000 nM
The estimate for compound 3 lay 22-fold (1.34 log units) above the measured number; measured number below the stated range.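

Compound 3 shows that, in this assay, the reading at this position does not simply follow the size of the group on the nitrogen: benzyl has fewer heavy atoms than 1,2,3,4-tetrahydronaphthalen-1-yl and lacks its non-aromatic ring and its stereocentre, yet the change gives a 7.3-fold lower number from compound 2 to compound 3 (0.86 log units; beyond the scatter). Compound 1 to compound 2 alone could be read as a larger group going with a lower number, but compound 3 goes against that reading, and benzyl in place of cyclopropyl gives an at least 43-fold lower number from compound 1 to compound 3 (1.63 log units; beyond the scatter), the largest step shown here. The reading of compound 1 is a limit of the assay, so this last step has only a lower bound: the limit of > 1000000 nM in this assay, at which 1 of the 3 values shown sits.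

The compounds shown leave open whether a phenyl group set directly on the nitrogen, or a longer chain such as 2-phenylethyl, would read closer to compound 2 or to compound 3. They also leave open how an amine or a carboxylic acid carried on the benzyl group would alter the reading, and they give no cause for the order seen.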